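Replacing dimethylamino with methyl on the chain of compound 3

A few compounds are considered here, and "the series" means these few. Any claim that something is new, unique, unknown or untested is made for them only; others in the source may bear on it.

Measured in a functional assay on MCF7 cells (Homo sapiens) for antiproliferative activity, read by MTT assay, with a stated time of 48 h; a lower number here means a stronger inhibitor, a higher number a weaker inhibitor:
- compound 1 `COc1cccc(C(=O)Nc2cc3cnc(NCCN(C)C)cc3n(C)c2=O)c1`: 43300 nM
- compound 2 `CN(C)CCNc1cc2c(cn1)cc(NC(=O)c1ccccc1)c(=O)n2C`: 35100 nM
- compound 3 `CN(C)CCNc1cc2c(cn1)cc(NC(=O)c1cccc(-c3ccccc3)c1)c(=O)n2C`: 1930 nM

Compound 3 has the lowest number of the three, with steps to both others beyond the scatter. Compound 4 `CCCNc1cc2c(cn1)cc(NC(=O)c1cccc(-c3ccccc3)c1)c(=O)n2C` differs from it on the chain: methyl in place of dimethylamino on a saturated chain carbon, two bonds along the chain from a nitrogen on an aromatic ring. Within the data shown here, no measured step touches this chain. All three lie on an aromatic carbon: a 1.2-fold lower number from compound 1 to compound 2 (0.09 log units; within the scatter) stayed within the scatter, while an 18-fold lower number from compound 2 to compound 3 (1.26 log units; beyond the scatter) and a 22-fold lower number from compound 1 to compound 3 (1.35 log units; beyond the scatter) were large. They show only how far values in this assay can move within the series. A moderate rise is tentatively expected, as a 2.1-fold higher number from compound 3 to compound 4 (0.32 log units; beyond the scatter). For compound 4 the estimated value is 4000 nM, with an expected range of 1200 nM to 15000 nM.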

Compound 4, half-maximal inhibitory concentration: 6000 nM
Beside the measured number, compound 4's estimate is 1.5-fold (0.18 log units) below it, and the stated range covers the measured number.
By their numbers in this assay, from the lowest: compound 3; then compound 4; then compounds 2 and 1 (each within the scatter of the next).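

In this assay, the chain now has its first measured step: a 3.1-fold higher number from compound 3 to compound 4 (0.49 log units; beyond the scatter), with propylamino in place of (2-(dimethylamino)ethyl)amino. This step is modest beside the large steps on the aromatic carbon, so in this pair, antiproliferative activity does not depend wholly on the dimethylamino group. Nothing available explains this change.

Still open, on these data alone, is whether a primary amine, a morpholine or a longer chain carrying dimethylamino would give a lower or higher number. The same chain change on compound 1 or compound 2 could also differ in size.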